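Swapping the Aryl Group of Compound 2 for 4-Cyanophenyl

A few compounds are considered here, and "the series" means these few. Any claim that something is new, unique, unknown or untested is made for them only; others in the source may bear on it.

Of the compounds shown here, three have been measured so far in a functional assay on LNCaP cells (Homo sapiens) for antiproliferative activity, read by propidium iodide staining, with a stated time of 96 h; a higher number here means a weaker inhibitor, a lower number a stronger inhibitor. Compound 1 (`CC(O)(COc1cccc(S(F)(F)(F)(F)F)c1)C(=O)Nc1ccc(S(F)(F)(F)(F)F)cc1`) at 12000 nM and compound 3 (`CC(O)(COc1cccc(OC(F)(F)F)c1)C(=O)Nc1ccc(S(F)(F)(F)(F)F)cc1`) at 11000 nM lie within the scatter of each other, while compound 2 (`CC(O)(COc1cccc(C(F)(F)F)c1)C(=O)Nc1ccc(S(F)(F)(F)(F)F)cc1`) at 24700 nM holds the highest number of the three. Compound 2 is the weakest inhibitor of this set, and its steps to both others lie beyond the scatter.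

Compound 4 (`CC(O)(COc1ccc(C#N)cc1)C(=O)Nc1ccc(S(F)(F)(F)(F)F)cc1`) has not yet been measured. It carries 4-cyanophenyl in place of 3-(trifluoromethyl)phenyl on an oxygen on a saturated carbon as its change from compound 2. The measured steps bear on this only loosely. Each swaps one group on an aromatic carbon, and they stay small: the data show a 2.1-fold higher number from compound 1 to compound 2 (0.31 log units; beyond the scatter) and a 1.1-fold lower number from compound 1 to compound 3 (0.04 log units; within the scatter) and nothing much larger. For the measured compounds named here, none of the measured compounds holds a nitrile, so these steps guide only the size of the change. Compound 2 at 24700 nM sits above both other values, so a modest drop is expected, similar in size to a 2.2-fold lower number from compound 2 to compound 3 (0.35 log units; beyond the scatter) in the same direction. The estimate amounts to a 1.5-fold lower number from compound 2 to compound 4 (0.19 log units; within the scatter) as the expected step. Compound 4 is expected at 16000 nM within an estimated range of 6000 nM to 40000 nM in this assay for now.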

Compound 4, half-maximal inhibitory concentration: 100000 nM
Compound 4: middle estimate off by 6.3-fold (0.80 log units), on the low side; the whole stated range lies below it.
By their numbers in this assay, from the lowest: compounds 3 and 1 (each within the scatter of the next); then compound 2; then compound 4.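

Across this assay, the move from 3-(trifluoromethyl)phenyl to 4-cyanophenyl on an oxygen on a saturated carbon gives the largest step seen so far (a 4.0-fold higher number from compound 2 to compound 4 (0.61 log units; beyond the scatter)), and it runs toward weaker inhibition. For the compounds shown here, the earlier steps swapped only one group on an aromatic carbon and stayed smaller, so this result is the first to show that the aryl group at this place can shift the number well beyond the small movements seen among compounds 1, 2 and 3. No measurement shown here accounts for the rise, and the step itself does not explain it.

The compounds shown leave open whether the change follows the nitrile itself or the different place it takes on the ring, since the two groups differ in both their substituent and its numbered position in a single step. They also leave open how a chlorine atom, an amine or a carboxylic acid would read at this place, and whether any aryl group here can bring the number below those of compounds 1 and 3.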